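Changing the thio-linked side chain of compound 3

A few compounds are considered here, and "the series" means these few. Any claim that something is new, unique, unknown or untested is made for them only; others in the source may bear on it.

Measured in a functional assay on MV4-11 cells (Homo sapiens) for antiproliferative activity, read by CellTiter-Glo, with a stated time of 72 h; a higher number here means a weaker inhibitor of growth, a lower number a stronger inhibitor of growth:
- Compound 1 `COCC(=O)N[C@H]1CC[C@H](Nc2cc(-c3csc(NCC4CCOCC4)n3)c(Cl)cn2)CC1`: > 10000 nM, a limit of the assay
- Compound 2 `COC[C@H](C)N[C@H]1CC[C@H](Nc2cc(-c3csc(NCC4CCOCC4)n3)c(Cl)cn2)CC1`: 440 nM
- Compound 3 `COCCN[C@H]1CC[C@H](Nc2cc(-c3csc(SCC4CCOCC4)n3)c(Cl)cn2)CC1`: 340 nM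

Compound 3 stands within the scatter of compound 2, so their two values show no order. Compound 4 `COCCN[C@H]1CC[C@H](Nc2cc(-c3csc(NCC4CCCC4)n3)c(Cl)cn2)CC1` carries (cyclopentylmethyl)amino in place of ((oxan-4-yl)methyl)sulfanyl on an aromatic carbon. For the measured compounds named here, the only measured step, an at least 22-fold lower number from compound 1 to compound 2 (1.35 log units; beyond the scatter), is large, but it lies on an amine nitrogen, not at this place, so no measured step bears directly on the change. No shift beyond the scatter is therefore expected in this assay, in either direction, starting from compound 3 at 340 nM. The estimated step is a 1.1-fold lower number from compound 3 to compound 4 (0.05 log units; within the scatter). For compound 4 the expected value is 300 nM, with an estimated range of 80 nM to 1200 nM.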

Compound 4, concentration for 50% growth inhibition: 2160 nM
The estimate for compound 4 lay 7.2-fold (0.86 log units) below the measured number; the whole stated range lies below it.
By their numbers in this assay, from the lowest: compounds 3 and 2 (each within the scatter of the next); then compound 4. At a limit, above all of these: compound 1.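

In this assay, for the compounds shown here, the group on this aromatic carbon proves to matter, with a 6.4-fold higher number from compound 3 to compound 4 (0.80 log units; beyond the scatter) as the first measured step at this place. The exchange replaces the linking sulfur and the oxane ring together, so the step cannot be assigned to either one alone. Nothing measured here gives a cause for the step.

As far as these compounds go, it remains open whether the sulfur or the oxane ring carries the difference. The outcome with (cyclopentylmethyl)sulfanyl, or with an open butylamino chain, on this carbon is also unknown.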